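Adding a ring methyl to compound 2

The source may hold more compounds than are shown below. What is called first, only, known or untested is meant among the compounds shown, and "the series" means these compounds.

Of the compounds shown here, two have been measured so far, compound 1 `CC(=O)N(C)C(C)C#CCn1cncc1C` and compound 2 `CC(=O)N(C)CC#CCn1ccnc1`, both in a functional assay on the whole organism for agonist activity, with Mus musculus as the target; on this read-out higher numbers stand for an effect only at larger amounts of compound and lower numbers for an effect already at smaller amounts. For the measured compounds named here, compound 2 gives 0.97 mg/kg, the only actual number. Compound 1 gives > 100 mg/kg, which is a limit of the assay and not a number. Going by the values given here, these two compounds differ in more than one place, and their values show only that one has a number and the other a limit.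

Compound 3 `CC(=O)N(C)CC#CCn1cncc1C` departs from compound 2 in a single place: methyl in place of hydrogen on an aromatic carbon. Among the compounds with values here, no measured step isolates this change, so any expectation is weakly founded. Compound 3 shares this ring methyl with compound 1, whose reading of > 100 mg/kg is again a limit. The expected shift is therefore toward larger doses, and the estimated size is an 8.2-fold higher number from compound 2 to compound 3 (0.92 log units; beyond the scatter) in this assay. For compound 3 the estimated dose is 8 mg/kg, with an expected range of 1 mg/kg to 70 mg/kg.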

Compound 3, dose for half-maximal effect: 5.4 mg/kg
Compound 3: the middle estimate sits 1.5-fold (0.17 log units) above what was measured, and the stated range covers the measured number.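

In this assay, methyl in place of hydrogen on the aromatic carbon next to the ring atom that bears a group of 9 heavy atoms now has a measured size, a 5.6-fold higher number from compound 2 to compound 3 (0.75 log units; beyond the scatter), and compound 3 still reads as an actual number. The ring methyl alone therefore does not account for the limit of compound 1, and hydrogen in place of methyl on the saturated chain carbon bound to an amide-type nitrogen and a triple-bonded carbon gives an at least 18-fold lower number from compound 1 to compound 3 (1.26 log units; beyond the scatter). That step starts from a limit and not a number, so its size is only a bound: the limit of > 100 mg/kg in this assay, at which 1 of the 3 values shown sits.

The compounds shown leave open how the chain methyl reads on a ring without the ring methyl, and so whether the two methyl groups add up or one outweighs the other. Also open, going by these compounds, is whether an ethyl group or a chlorine on the same aromatic carbon would move the dose further than methyl does, or less.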